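Swapping amino for hydroxy on the cyclohexyl ring

The source may hold more compounds than are shown below. What is called first, only, known or untested is meant among the compounds shown, and "the series" means these compounds.

Two compounds share a urea core carrying a pyridinylmethyl group and a sulfonyl group on a benzene ring. Compound 1 `O=C(NCc1cccnc1)Nc1ccc(S(=O)(=O)N2CC3(COC3)C2)cc1` bears a spiro bicyclic amine on the sulfonyl sulfur, and in an assay on isolated protein for inhibition of Nicotinamide phosphoribosyltransferase (Homo sapiens), read by spectrophotometry, with stated times of 15 min and 30 min (a higher number here means a weaker inhibitor, a lower number a stronger inhibitor), compound 1 gives 103 nM. Compound 2 `N[C@H]1CC[C@H](NS(=O)(=O)c2ccc(NC(=O)NCc3cccnc3)cc2)CC1` instead carries a 4-aminocyclohexyl group attached through an amide-type nitrogen, and in this assay compound 2 gives 4 nM. Within the data shown here, the only step between measured compounds is a 26-fold lower number from compound 1 to compound 2 (1.41 log units; beyond the scatter), which leaves compound 2 with the lowest number of the two. Compound 3 `O=C(NCc1cccnc1)Nc1ccc(S(=O)(=O)N[C@H]2CC[C@H](O)CC2)cc1` differs from compound 2 by hydroxy in place of amino on a saturated ring carbon. Among the measured compounds shown here, no measured step follows exactly this change; the one measured step replaced the whole sulfonyl substituent, and its large size only shows that the group on the sulfonyl sulfur matters to this assay. A moderate weakening is therefore expected, with compound 3 estimated at 20 nM within a range of 5 nM to 80 nM, corresponding to an expected step of a 5.0-fold higher number from compound 2 to compound 3 (0.70 log units; beyond the scatter).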

Compound 3, half-maximal inhibitory concentration: 8 nM
Estimate against measurement, compound 3: 2.5-fold (0.40 log units) above; low and high end bracket the measured number.
By their numbers in this assay, from the lowest: compounds 2 and 3 (each within the scatter of the next); then compound 1.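

In this assay, hydroxy in place of amino on a saturated ring carbon of the cyclohexyl ring gives a 2.0-fold higher number from compound 2 to compound 3 (0.30 log units; within the scatter), so the two groups cannot be told apart at this position, three ring bonds from the ring atom that bears the large group. The result also separates the amino group from the earlier gain: with hydroxy at this place, the change of group on the sulfonyl sulfur still gives a large step (a 13-fold lower number from compound 1 to compound 3 (1.11 log units; beyond the scatter)), so that gain does not need the amino group and holds with either of these two groups. Nothing measured here explains why amino and hydroxy read so alike.

The compounds shown leave open whether this position needs such a group at all, as a plain cyclohexyl ring with only hydrogen there would test. They also leave open how far the tolerance extends, for instance to a methoxy group, a carboxylic acid or a longer chain such as aminomethyl, each of which would show whether the closeness of amino and hydroxy extends to other groups.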